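The source may hold more compounds than are shown below. What is called first, only, known or untested is meant among the compounds shown, and "the series" means these compounds.

Working notes on the arylpiperazine amide series, followed in an assay on isolated protein (Vas deferens, strain Sprague-Dawley) for antagonist activity at Alpha-1A adrenergic receptor (Rattus norvegicus), with a stated time of 20 min; on this read-out lower numbers stand for tighter binding and higher numbers for weaker binding.

Going by the values given here, compound 1 `COc1ccccc1N1CCN(CCCNC(=O)Cc2c[nH]c3ccccc23)CC1` gives 7.94 nM in this assay, the lowest of the two numbers so far. Among the compounds with values here, compound 2 `COc1ccccc1N1CCN(CCCNC(=O)CCCc2c[nH]c3ccccc23)CC1` gives 12.6 nM in this assay; no step between the two is computed here, and the two values lie within the scatter of each other, so nothing is read from them about the length of the chain between the amide and the indole.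

Compound 3 `COc1ccccc1N1CCN(CCCNC(=O)c2cn(C)c3ccccc23)CC1` has not yet been measured in this assay. It differs from compound 1 in one place: 1-methyl-1H-indol-3-yl in place of (1H-indol-3-yl)methyl on a carbonyl carbon. The same atoms are rearranged, so the carbonyl now sits directly on the ring, and the ring hydrogen-bond donor is replaced by a methyl.

Within the data shown here, with no measured step of this kind to lean on, and compound 1 at 7.94 nM, compound 3 is estimated at 20 nM, range 4 nM to 100 nM. The step implied, a 2.5-fold higher number from compound 1 to compound 3 (0.40 log units; beyond the scatter), is expected to be a modest loss, possibly no more than the scatter.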

Compound 3, dissociation constant: 52.5 nM
The estimate for compound 3 lay 2.6-fold (0.42 log units) below the measured number; the measured number falls inside the stated range.
By their numbers in this assay, from the lowest: compounds 1 and 2 (each within the scatter of the next); then compound 3.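

Going by these compounds alone, replacing (1H-indol-3-yl)methyl with 1-methyl-1H-indol-3-yl on the carbonyl carbon gives a 6.6-fold higher number from compound 1 to compound 3 (0.82 log units; beyond the scatter) in this assay and so provides the first step beyond the scatter, showing that this position responds to how the same atoms are joined, whereas the values of compound 1 and compound 2 lay within the scatter of each other. The step combines two changes, with the carbonyl now directly on the ring and the ring hydrogen-bond donor replaced by a methyl, so it cannot be assigned to either one alone. No measured evidence bears on the cause of this step.

As far as these compounds go, it remains open which change carries the step; the unmethylated 1H-indol-3-yl on the carbonyl carbon and (1-methyl-1H-indol-3-yl)methyl would separate the two. Also open, from the compounds shown here alone, is how a larger 1-ethyl group on the indole would read.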